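The source may report more compounds than this note shows. Statements on the series, on what has been measured and on what is new or still open speak of the compounds shown alone.

Among the measured compounds shown here, in an ADME assay on microsomes from liver (Homo sapiens) for metabolic stability, with a stated time of 60 min, tested at 1 uM (a higher number here means that more of the compound is left, a lower number that less of the compound is left), compound 1 `COc1cc(-c2cnn3cc(OC)c(C(C)(C)O)nc23)ccn1` gives 66%, the highest of the three numbers so far. Compound 2 `Cn1cc(-c2nc3c(-c4ccnc(OC5CC5)c4)cnn3cc2OCCCC(C)(C)O)cn1` gives 54% and compound 3 `Cn1cc(-c2nc3c(-c4ccnc(OC5CC5)c4)cnn3cc2OCC(C)(C)O)cn1` gives 53%, both beyond the scatter from compound 1. Compound 4 `COc1cc(-c2cnn3cc(OC)c([C@H]4COC(C)(C)C4)nc23)ccn1` remains unmeasured and differs from compound 1 as follows: a group of 7 heavy atoms (6 carbon, 1 oxygen; one five-membered non-aromatic ring with 1 hetero atom) in place of a group of 4 heavy atoms (3 carbon, 1 oxygen; no ring), on an aromatic carbon. For the measured compounds named here, the only measured step, a number 1 percentage points lower from compound 2 to compound 3 (within the scatter), concerns a different group on a different chain, and no measured step touches this place on the core of compound 1. It therefore gives only weak guidance, and the direction remains uncertain. The expected change is a moderate fall, with a number 18 percentage points lower from compound 1 to compound 4 (beyond the scatter) as the estimated step. For compound 4 the estimated value is 48%, with an expected range of 27% to 68%.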

Compound 4, percent of the compound remaining: 21%
Estimate against measurement, compound 4: 27 percentage points above, outside the stated range (below it).
By their numbers in this assay, from the lowest: compound 4; then compounds 3 and 2 (each within the scatter of the next); then compound 1.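

In this assay, the step of a number 45 percentage points lower from compound 1 to compound 4 (beyond the scatter) shows that this aromatic carbon, next to the ring nitrogen, is sensitive to the group it carries. Exchanging 1-hydroxy-1-methylethyl for the five-membered non-aromatic ring is a large change in the amount of compound left, unlike the step within the scatter on the chain of compounds 2 and 3. No data bear on the reason for this fall. Open, from the compounds shown here alone, is how an amine or a 1-methoxy-1-methylethyl group at this place would read, and whether the other configuration of the stereocentre would differ from compound 4.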